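A few compounds are considered here, and "the series" means these few. Any claim that something is new, unique, unknown or untested is made for them only; others in the source may bear on it.

Measured compounds and their values:

Compound 1, `CCCCCON1C(=O)[C@@H](NC(=O)OCCCCC2CCCCC2)[C@@H]1C`: 387 nM
Compound 2, `CC(=O)CCCON1C(=O)[C@@H](NC(=O)OCCCCC2CCCCC2)[C@@H]1C`: 75 nM
Compound 3, `C[C@H]1[C@H](NC(=O)OCCCCC2CCCCC2)C(=O)N1Oc1ccc(S(C)(=O)=O)cc1`: 6 nM

The three compounds were tested in an assay on HEK293 cells for inhibition of N-acylethanolamine-hydrolyzing acid amidase (Homo sapiens), read by fluorescence, with stated times of 10 min and 50 min; a lower number here means a stronger inhibitor, a higher number a weaker inhibitor. Compound 1 has the highest number of the three; its nearest neighbour is compound 2, and its furthest is compound 3.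

The step considered here leads from compound 1 to compound 4, `C[C@H]1[C@H](NC(=O)OCCCCC2CCCCC2)C(=O)N1Oc1ccccc1S(C)(=O)=O`. The change is 2-(methylsulfonyl)phenyl in place of pentyl on an oxygen.

Going by the values given here, two measured steps bear on this change. The closest is the step of a 65-fold lower number from compound 1 to compound 3 (1.81 log units; beyond the scatter), where the group on the oxygen is likewise replaced by a methylsulfonyl-bearing phenyl, there 4-(methylsulfonyl)phenyl. The step of a 5.2-fold lower number from compound 1 to compound 2 (0.71 log units; beyond the scatter) shows that a smaller change on the same pentyl chain already lowers the number, and the step of a 13-fold lower number from compound 2 to compound 3 (1.10 log units; beyond the scatter) shows the aromatic replacement going further still. For compound 4 a lower number than for compound 1 is therefore expected, in the same direction as for compound 3, though the 2-(methylsulfonyl)phenyl group has not itself been measured, so the size is less certain.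

The expected step is a 26-fold lower number from compound 1 to compound 4 (1.41 log units; beyond the scatter). Compound 4 is thus estimated at 15 nM, within a range of 4 nM to 60 nM.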

Compound 4, half-maximal inhibitory concentration: 6 nM
For compound 4 the middle estimate is 2.5-fold (0.40 log units) above the measured one; the range from low to high includes it.
By their numbers in this assay, from the lowest: compounds 3 and 4 (each within the scatter of the next); then compound 2; then compound 1.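

In this assay, the result shows that this position on the oxygen bound to the amide-type nitrogen in a ring tolerates more than one placement of the methylsulfonyl group on the phenyl, as 2-(methylsulfonyl)phenyl in place of 4-(methylsulfonyl)phenyl gives no change at the digits printed from compound 3 to compound 4 (within the scatter). The gain over the two open-chain groups is thus no longer tied to a single aromatic group: the pentyl comparison gives a 65-fold lower number from compound 1 to compound 4 (1.81 log units; beyond the scatter), and the 3-acetylpropyl comparison gives a 13-fold lower number from compound 2 to compound 4 (1.10 log units; beyond the scatter), the same sizes as those seen with compound 3. Nothing shown here gives a measured reason for these steps.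

Still open, going by these compounds, is how much of this depends on the methylsulfonyl group itself, which a plain phenyl, or a phenyl carrying a carboxylic acid in its place, on the same oxygen would help to settle. On these data alone, it is also open whether compound 3 and compound 4 would remain level if the chain shared by all the compounds were replaced, for example by a plain octyl chain.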